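Moving a methoxy for a fluoro on two related cores

The compounds below may be only part of what the source reports. "The series", "measured", "known", "first", "only" and "open" are said of these compounds alone.

Compound 1 `COc1ccc(-c2ccc(C(=O)Nc3ccc(Oc4ccnc5[nH]ccc45)c(F)c3)nc2)cc1` and compound 3 `COc1ccc(-c2ccnc(C(=O)Nc3ccc(Oc4ccnc5[nH]ccc45)c(F)c3)c2)cc1` share the same atoms joined in different ways; the difference between the two cores is not broken down here. Among the measured compounds shown here, in a functional assay on PC-3 cells (Homo sapiens) for cytotoxicity, read by MTT assay, with a stated time of 72 h (a lower number here means a stronger inhibitor, a higher number a weaker inhibitor), compound 1 gives 650 nM, while compound 3 gives 20 nM, the lowest of the three numbers measured so far.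

Compound 2 `O=C(Nc1ccc(Oc2ccnc3[nH]ccc23)c(F)c1)c1ccc(-c2ccc(F)cc2)cn1` differs from compound 1 by a single change, (fluoro in place of methoxy on an aromatic carbon). That change produced a 21-fold higher number from compound 1 to compound 2 (1.31 log units; beyond the scatter), and in this assay compound 2 gives 13400 nM.

Compound 4 `O=C(Nc1ccc(Oc2ccnc3[nH]ccc23)c(F)c1)c1cc(-c2ccc(F)cc2)ccn1` has not yet been measured. It stands to compound 3 as compound 2 stands to compound 1: the change is fluoro in place of methoxy on an aromatic carbon, and since the place is described in the same words for both pairs, it is the same change made on the core of compound 3 instead of the core of compound 1.

On that basis the step from compound 3 to compound 4 in this assay is expected to be of a similar size to the step already seen, an 18-fold higher number from compound 3 to compound 4 (1.24 log units; beyond the scatter), because the earlier step of a 21-fold higher number from compound 1 to compound 2 (1.31 log units; beyond the scatter) was large and beyond the scatter. For the measured compounds named here, the expectation rests on only one measured pair, so a weaker outcome on the core of compound 3 cannot be ruled out. Compound 4 is therefore estimated at 350 nM, with a likely range from 100 nM to 1500 nM.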

Compound 4, half-maximal inhibitory concentration: 710 nM
Beside the measured number, compound 4's estimate is 2.0-fold (0.31 log units) below it; measured number inside the range.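

In this assay, the change from 4-methoxyphenyl to 4-fluorophenyl on the core of compound 3 gave a 36-fold higher number from compound 3 to compound 4 (1.55 log units; beyond the scatter), so the number rose on this core as it had on the core of compound 1. Set side by side, the two steps point the same way, are both large, and cannot be told apart in size, which means that in this pair of cores the change carried over from one to the other: the same change on two cores in this assay, a 21-fold higher number (1.31 log units; beyond the scatter) from compound 1 to compound 2 and a 36-fold higher number (1.55 log units; beyond the scatter) from compound 3 to compound 4, 1.7-fold (0.24 log units) apart, within the scatter of two such steps. Among the compounds shown here, this rests on only two matched pairs, one pair of groups and a single assay, so it does not show that the change would behave the same way on any further core or in any other assay, and it gives no reason why either step has the size it has.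

The compounds shown carry only methoxy or fluoro on this aromatic carbon, which leaves open what a hydroxyl, a chloro, an amine or a longer alkoxy chain would give in the same place. They also leave open whether a change of a different kind, such as a carboxylic acid in place of the methoxy, would carry over between these two cores as faithfully as this one did.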